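The source may report more compounds than this note shows. Statements on the series, on what has been measured and on what is new or still open speak of the compounds shown alone.

Compound 1 (`COc1cc2nccc(Oc3ccc(Nc4nn(C)cc4C(=O)NC45CCC(CC4)CC5)cc3)c2cc1C(N)=O`) gives > 10000 nM in a functional assay on BaF3 cells (Mus musculus) for antiproliferative activity, read by CCK-8 assay and cell counting, with a stated time of 76 h (a higher number here means a weaker inhibitor, a lower number a stronger inhibitor), and this reading is a limit and not a number. Compound 2 (`COc1cc2nccc(Oc3ccc(Nc4nn(C)cc4C(=O)NCC(C)C)cc3)c2cc1C(N)=O`) gives > 10000 nM in this assay and this too is only a limit. Compound 2 therefore has no exact potency and stands at the limit of > 10000 nM in this assay, at which 2 of the 2 values shown sit, in the data so far.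

Within the data shown here, the one measured change of the group on the amide-type nitrogen is a step that the two limits leave unreadable from compound 1 to compound 2 and so offers no size to carry forward.

Compound 3 (`COc1cc2nccc(Oc3ccc(Nc4nn(C)cc4C(=O)NCC4CCCCC4)cc3)c2cc1C(N)=O`) differs from compound 2 by cyclohexyl in place of isopropyl on a saturated chain carbon bound to an amide-type nitrogen and the same difference can be read as isobutyl to cyclohexylmethyl. The new group brings a six-membered non-aromatic ring of carbon only. Compound 1 already carries two such rings on its amide-type nitrogen and still reads > 10000 nM as a limit, so the ring alone is not expected to bring a gain.

The expected step is a number no higher from compound 2 to compound 3 (the limit leaves the size open) and no change beyond the usual scatter is anticipated in this assay for either direction. For compound 3 the estimate is 10000 nM with an expected range from 5000 nM to 20000 nM and a reading that is again only a limit is the likeliest outcome.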

Compound 3, half-maximal inhibitory concentration: > 10000 nM
Compound 3 gave a limit, no number; the forecaster's own chance of this, stated with the estimate: 85%; the middle value lies on the limit itself.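

No step among compound 1, compound 2 and compound 3 can be read, as each reading is a limit and not a number: the limit of > 10000 nM in this assay, at which 3 of the 3 values shown sit.

The compounds shown leave open how weak each of the three truly is in this assay, and whether any group on the amide-type nitrogen can give a measurable potency there.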